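Mirror-image pair in a fused bicyclic series

The compounds below may be only part of what the source reports. "The series", "measured", "known", "first", "only" and "open" are said of these compounds alone.

For the measured compounds named here, compound 2 `CS(=O)(=O)Nc1ccc2c(c1)S(=O)(=O)N=C(C1=C(O)[C@H]3CCCC[C@H]3N(Cc3ccc(F)cc3)C1=O)N2` stands highest of the two numbers so far in an ADME assay on microsomes from liver (Homo sapiens) for metabolic stability, with a stated time of 60 min, tested at 1 uM (a lower number here means that less of the compound is left, a higher number that more of the compound is left), where compound 2 gives 99%. Its nearest neighbour is compound 1 `CS(=O)(=O)Nc1ccc2c(c1)S(=O)(=O)N=C(C1=C(O)C3CCCCC3N(Cc3ccc(F)cc3)C1=O)N2`, which in this assay gives 81%. Going by the values given here, the single measured step, a number 18 percentage points higher from compound 1 to compound 2 (beyond the scatter), is the only one that bears on the question; it goes together with the fact that one of compounds 1 and 2 is drawn with a defined configuration and the other without, at the place where they differ, so compound 1 may hold both mirror forms. Compound 3 `CS(=O)(=O)Nc1ccc2c(c1)S(=O)(=O)N=C(C1=C(O)[C@@H]3CCCC[C@@H]3N(Cc3ccc(F)cc3)C1=O)N2` differs from compound 2 in that (the two compounds have the same atoms and bonds and differ only in configuration as drawn: 2 of 2 stereo elements differ (all stereocentres are inverted: mirror images); a stereocentre at a saturated ring carbon is drawn S in compound 2 and R in compound 3; a stereocentre at a saturated ring carbon is drawn R in compound 2 and S in compound 3). If compound 1 holds compound 2 and compound 3 in equal share, the number of the mixture should sit between the two single forms, and compound 3 should then lie about as far under compound 1 as compound 2 lies over it. Compound 3 is therefore expected to give 63% in this assay, within a range from 45% to 82%. The expected step of a number 36 percentage points lower from compound 2 to compound 3 (beyond the scatter) is downward and beyond the scatter.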

Compound 3, percent of the compound remaining: 80%
Beside the measured number, compound 3's estimate is 17 percentage points below it; the measured number falls inside the stated range.
By their numbers in this assay, from the lowest: compounds 3 and 1 (each within the scatter of the next); then compound 2.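

Configuration at the two ring stereocentres now stands as a variable in its own right in this assay, with a number 19 percentage points lower from compound 2 to compound 3 (beyond the scatter) and no atom or bond changed: the fact that compounds 2 and 3 differ only in the configuration as drawn. The effect is one-sided, since the other comparison gives a number 1 percentage points lower from compound 1 to compound 3 (within the scatter), so only compound 2 separates from the other two. Compound 1 therefore reads alongside compound 3 and does not sit midway between the two single forms, which is a comparison that rests on a difference in drawn configuration alone: the fact that one of compounds 1 and 3 is drawn with a defined configuration and the other without, at the place where they differ.

As far as these compounds go, the composition of compound 1 remains unknown, so the values do not tell whether it holds the mirror forms in equal share. Also open, from the compounds shown here alone, are the forms with only one of the two stereocentres inverted, and whether the gap between the mirror forms persists with a carboxylic acid or an amine in place of the fluorine.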